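Replacing the styryl arm of a bile acid receptor ligand

The compounds below may be only part of what the source reports. "The series", "measured", "known", "first", "only" and "open" are said of these compounds alone.

Measured compounds in an assay on isolated protein with Bile acid receptor (Homo sapiens) as the target; a higher number here means that more compound is needed for the effect, a lower number that less compound is needed:
compound 1 `COC(=O)/C=C/c1cccc(N(Cc2ccc(/C=C/c3cccc(Cl)c3)cc2)C(=O)C2CCCCC2)c1` gives 166 nM;
compound 2 `COC(=O)/C=C/c1cccc(N(Cc2ccc(/C=C/c3cccc(Cl)c3)cc2)C(=O)C(C)C)c1` gives 162 nM;
compound 3 `COC(=O)/C=C/c1cccc(N(Cc2ccc(/C=C/c3ccc(F)cc3)cc2)C(=O)C2CCCCC2)c1` gives 186 nM.

Compound 2 stands among numbers that all lie within the scatter of one another, so no order among them can be claimed. The step of a 1.0-fold lower number from compound 1 to compound 2 (0.01 log units; within the scatter) and the step of a 1.1-fold higher number from compound 1 to compound 3 (0.05 log units; within the scatter) both stayed within the scatter. Compound 4 `COC(=O)/C=C/c1cccc(N(Cc2ccc(-c3cccc(OC)c3)cc2)C(=O)C(C)C)c1` differs from compound 2 in that (3-methoxyphenyl in place of 2-(3-chlorophenyl)ethenyl on an aromatic carbon). Neither measured step touches the double bond that leaves here; only the variation of the distal ring in compound 3 is loosely related, and it was within the scatter. With the linker itself removed, a step in this assay somewhat beyond the scatter toward a higher number is expected, a 2.5-fold higher number from compound 2 to compound 4 (0.39 log units; beyond the scatter). Compound 4 is estimated at 400 nM, in the range 120 nM to 1500 nM.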

Compound 4, half-maximal effective concentration: 72.4 nM
Compound 4: middle estimate off by 5.5-fold (0.74 log units), on the high side; measured number below the stated range.
By their numbers in this assay, from the lowest: compound 4; then compounds 2, 1 and 3 (each within the scatter of the next).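

Putting 3-methoxyphenyl in place of 2-(3-chlorophenyl)ethenyl gives, in this assay, a 2.2-fold lower number from compound 2 to compound 4 (0.35 log units; beyond the scatter), the only step shown that lies beyond the scatter. This position therefore responds to change where the earlier swaps did not, and the double bond outside aromatic rings is not required for a low number here. Nothing available explains the step.

The compounds shown leave open whether the loss of the double bond or the entry of the methoxy group accounts for it. A directly attached 3-chlorophenyl would be the telling comparison.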